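The compounds below may be only part of what the source reports. "The series", "measured", "known", "first", "only" and "open" are said of these compounds alone.

Compound 1, `Cc1ccccc1CCCCCCC(=O)N1CCCC1`, in an assay on HEK293 cells for inhibition of N-acylethanolamine-hydrolyzing acid amidase (Rattus norvegicus), read by LC-MS, with a stated time of 30 min; on this read-out lower numbers stand for stronger inhibition and higher numbers for weaker inhibition: 68400 nM.
Compound 2, `Cc1cccc(CCCCCCC(=O)N2CCCC2)c1`, in this assay: 8300 nM.
Compound 3, `O=C(CCCCCCc1ccc(F)cc1)N1CCCC1`, in this assay: 8000 nM.

Of these three numbers, compound 1 gives the highest; compound 2 and compound 3 both lie well below it, beyond the usual scatter, while the two of them are within the scatter of each other. Compound 4, `O=C(CCCCCCc1ccccc1Cl)N1CCCC1`, is not yet measured and differs from compound 1 in one place: chloro in place of methyl on an aromatic carbon. Among the compounds with values here, no measured pair shows this exchange, so its size can only be expected. Since the new group sits where the methyl of compound 1 stood, the account expects the step of a 1.7-fold lower number from compound 1 to compound 4 (0.23 log units; within the scatter) to be modest, if anything toward a lower number, and not clearly beyond the scatter. For compound 4 the estimate is 40000 nM, with a range from 12000 nM to 120000 nM.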

Compound 4, half-maximal inhibitory concentration: > 100000 nM
Compound 4 ended at the assay's limit; the forecaster's own chance of this, stated with the estimate: 10%; middle value at least 2.5-fold (0.39 log units) from the limit.
By their numbers in this assay, from the lowest: compounds 3 and 2 (each within the scatter of the next); then compound 1. At a limit, above all of these: compound 4.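

Compound 4 stands at a limit of this assay, so its reading is a bound and not a number. For chloro in place of methyl on an aromatic carbon ortho to a large group, the data give an at least 1.4-fold higher number from compound 1 to compound 4 (0.16 log units; that floor lies within the scatter). At this position, the exchange therefore brought no move toward a lower number in this assay, although the true size of the step cannot be read. As far as these compounds go, it remains open how far compound 4 lies past the limit, and whether methoxy or an amine at this position would give a lower number than compound 1.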